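The source may report more compounds than this note shows. Statements on the series, on what has been measured and on what is new or still open speak of the compounds shown alone.

Measured so far: compound 1 `[N-]=[N+]=Nc1cncc(Cn2ccsc2=N)c1`, compound 2 `[N-]=[N+]=Nc1cc(Cn2ccsc2=N)cnc1Cl` and compound 3 `[N-]=[N+]=Nc1cncc(Cn2ccnc2N[N+](=O)[O-])c1`. In an assay on M10 cells (Gallus gallus) for binding affinity to Neuronal acetylcholine receptor; alpha4/beta2 (Homo sapiens) (on this read-out lower numbers stand for stronger inhibition and higher numbers for weaker inhibition), compound 1 gives 8.3 nM. Compound 2 gives 0.47 nM. Compound 3 gives 5400 nM.

Compound 1 and compound 2 differ by chloro in place of hydrogen on an aromatic carbon, a change that produced an 18-fold lower number from compound 1 to compound 2 (1.25 log units; beyond the scatter). How the core of compound 3 differs from the core of compound 1 is not broken down here; its number in this assay is the highest of the three. Compound 4 `[N-]=[N+]=Nc1cc(Cn2ccnc2N[N+](=O)[O-])cnc1Cl` is not yet measured. It differs from compound 3 by chloro in place of hydrogen on an aromatic carbon, the same kind of change as that between compound 1 and compound 2, the place being para to a large group rather than para to a group of 7 heavy atoms. Resting on the size of an 18-fold lower number from compound 1 to compound 2 (1.25 log units; beyond the scatter), compound 4 is expected to show a 14-fold lower number from compound 3 to compound 4 (1.13 log units; beyond the scatter) in this assay. Compound 4 is thus estimated at 400 nM, with a likely span from 100 nM to 2000 nM.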

Compound 4, inhibition constant: 300 nM
The estimate for compound 4 lay 1.3-fold (0.12 log units) above the measured number; low and high end bracket the measured number.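

In this assay, chloro in place of hydrogen on an aromatic carbon gave an 18-fold lower number from compound 3 to compound 4 (1.26 log units; beyond the scatter) on the core of compound 3, and this step sits beside the earlier one on the core of compound 1: the same change on two cores in this assay, an 18-fold lower number (1.25 log units; beyond the scatter) from compound 1 to compound 2 and an 18-fold lower number (1.26 log units; beyond the scatter) from compound 3 to compound 4, 1.0-fold (0.01 log units) apart, within the scatter of two such steps. The size of the change therefore carried over between these two cores. This rests on two pairs in a single assay, and it shows neither why the step held nor that it would hold on any further core.

The compounds shown leave open whether fluoro, bromo or methyl in that place would give a step of similar size. They also leave open whether the chloro step would persist with an amine in place of the azido group.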